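This account rests on a few compounds, and the source may have more. Where it says the series, first, only, none or still open, it means among the compounds named here.

In a functional assay on MGC-803 cells (Homo sapiens) for cytotoxicity, read by MTT assay, with a stated time of 72 h (a lower number here means a stronger inhibitor, a higher number a weaker inhibitor), compound 1 (`COc1cc(C=C2C(=O)N(c3ccc(Cl)cc3)N(c3ccc(Cl)cc3)C2=O)cc(OC)c1OC`) gives 17300 nM and compound 2 (`COc1cccc(C=C2C(=O)N(c3ccc(Cl)cc3)N(c3ccc(Cl)cc3)C2=O)c1`) gives 26600 nM, so the two values lie within the usual scatter of each other. Compound 3 (`COc1ccc(C=C2C(=O)N(c3ccc(Cl)cc3)N(c3ccc(Cl)cc3)C2=O)cc1OC`) carries methoxy in place of hydrogen on an aromatic carbon, ortho to a methoxy group and para to a large group (methoxy in place of hydrogen on an aromatic carbon), turning 3-methoxyphenyl to 3,4-dimethoxyphenyl. For the measured compounds named here, no two measured compounds differ in one place, so nothing measured sizes this change directly. In this assay, the expected result is a 1.3-fold lower number from compound 2 to compound 3 (0.10 log units; within the scatter), with no step beyond the scatter expected. For compound 3, the estimated value is 21000 nM, with an expected range of 9000 nM to 50000 nM.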

Compound 3, half-maximal inhibitory concentration: > 128000 nM
Compound 3: only a limit was reported; the forecaster's own chance of this, stated with the estimate: 10%; middle value at least 6.0-fold (0.78 log units) away from the limit.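

In this assay, methoxy entering on the aromatic carbon ortho to a methoxy group and para to a large group, turning 3-methoxyphenyl to 3,4-dimethoxyphenyl, gives an at least 4.8-fold higher number from compound 2 to compound 3 (0.68 log units; beyond the scatter). Hydrogen in place of methoxy on an aromatic carbon gives an at least 7.3-fold higher number from compound 1 to compound 3 (0.86 log units; beyond the scatter), so adding or removing a single methoxy can each produce a step beyond the scatter, depending on which other methoxy groups the ring carries. The reading for compound 3 is a limit and not a number: the limit of > 128000 nM in this assay, at which 1 of the 3 values shown sits.

The compounds shown leave open how far beyond this limit compound 3 lies. They also leave open whether a hydroxyl, an amine or a fluorine atom on this carbon would give the same step as methoxy.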